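The source may hold more compounds than are shown below. What is called first, only, known or untested is meant among the compounds shown, and "the series" means these compounds.

Three compounds have so far been examined in an ADME assay on HEK-293T cells (Homo sapiens) for inhibition, read by CCK-8 assay, with a stated time of 48 h, tested at 20 uM; on this read-out higher numbers stand for more inhibition of growth at the one concentration tested and lower numbers for less inhibition of growth. Compound 1 (`N#C/C(=C\c1ccccc1OS(=O)(=O)c1ccccc1[N+](=O)[O-])C(=O)Nc1nnc(Cc2cccc3ccccc23)s1`) is reported as "not toxic" (no number reported), without a number, while compound 2 (`N#C/C(=C\c1ccccc1OS(=O)(=O)c1ccccc1[N+](=O)[O-])C(=O)Nc1nnc(Cc2ccccc2)s1`) gives 10% and compound 3 (`Cc1ccc(Cc2nnc(NC(=O)/C(C#N)=C/c3ccccc3OS(=O)(=O)c3ccc(C)cc3)s2)cc1`) gives 22%. Compound 3 thus holds the higher of the two numbers, and its gap to compound 2 lies beyond the scatter.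

The next structure is compound 4 (`Cc1ccc(Cc2nnc(NC(=O)/C(C#N)=C/c3ccccc3OS(=O)(=O)c3ccccc3[N+](=O)[O-])s2)cc1`), which has 2-nitrophenyl in place of 4-methylphenyl on a sulfonyl sulfur. Within the data shown here, no pair of measured compounds differs by this change alone, so its size cannot be read directly from the data. Among the measured compounds shown here, the only numerical guide is compound 2, which also has 2-nitrophenyl on a sulfonyl sulfur and gives 10%. Compound 1 has the same group but provides no number. On this thin evidence, a fall in this assay is expected rather than a rise, though it may prove only about as large as the scatter. The expected change is a modest decrease, a number 9 percentage points lower from compound 3 to compound 4 (within the scatter). For compound 4 the estimated value is 13%, with an expected range from 3% to 26%.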

Compound 4, percent growth inhibition at one concentration: 6%
For compound 4 the middle estimate is 7 percentage points above the measured one; the range from low to high includes it.
By their numbers in this assay, from the lowest: compounds 4 and 2 (each within the scatter of the next); then compound 3.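

In this assay the exchange of 4-methylphenyl for 2-nitrophenyl, on a sulfonyl sulfur whose other neighbours are oxygen on an aromatic ring, can now be read directly from a single pair, and the step is (a number 16 percentage points lower from compound 3 to compound 4 (beyond the scatter)) with everything else in the two structures held the same. With 2-nitrophenyl kept in that place, the second available pair, methyl in place of hydrogen on an aromatic carbon, gives (a number 4 percentage points lower from compound 2 to compound 4 (within the scatter)), so this methyl change is not resolved from the usual spread of the read-out, whereas the change on the sulfonyl sulfur is. No other measurement is available to account for either step.

From the compounds shown here alone, whether the step on the sulfonyl sulfur would hold on another background remains open, since it rests on one pair and compound 1 gives no number to compare. The compounds shown also leave open how this assay would respond if an amine or a carboxylic acid took the place of the nitro group on that aromatic ring.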